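The compounds below may be only part of what the source reports. "The series", "measured", "known", "first", "only" and "open" are said of these compounds alone.

Compound 1 `O=C(N/N=C/c1cccc(F)c1)c1cccnc1Nc1cccc(C(F)(F)F)c1` gives 58.3% in a functional assay on the whole organism (strain Wistar) for inhibition, with Rattus norvegicus as the target, read by paw edema, with a stated time of 30 min, at a dose of 10 mg/kg by the intraperitoneal route (on this read-out lower numbers stand for less inhibition and higher numbers for more inhibition at the one dose given (going by the name of the read-out)), which places it second highest of the three numbers measured: compound 3 `O=C(N/N=C/c1ccc(O)c(O)c1)c1cccnc1Nc1cccc(C(F)(F)F)c1` gives 51.4%, a value within the scatter of compound 1, while compound 2 `O=C(N/N=C/c1cccc(Cl)c1)c1cccnc1Nc1cccc(C(F)(F)F)c1` gives 77.8%. For the measured compounds named here, the only step from compound 1 beyond the scatter is a number 19.5 percentage points higher from compound 1 to compound 2 (beyond the scatter). Compound 4 `CN(C)c1ccc(/C=N/NC(=O)c2cccnc2Nc2cccc(C(F)(F)F)c2)cc1` differs from compound 1 in one place: 4-(dimethylamino)phenyl in place of 3-fluorophenyl on a carbon with a double bond to nitrogen. Going by the values given here, the steps that bear on this change are those exchanging the group on the carbon with a double bond to nitrogen, namely a number 6.9 percentage points lower from compound 1 to compound 3 (within the scatter) and a number 26.4 percentage points lower from compound 2 to compound 3 (beyond the scatter). Neither tests a 4-(dimethylamino)phenyl, so a larger move cannot be excluded, yet such exchanges have given no gain so far. Compound 4 is therefore expected to give an estimated 55%, with a range from 40% to 70%, a step of a number 3.3 percentage points lower from compound 1 to compound 4 (within the scatter) expected to stay within the scatter.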

Compound 4, a percentage reported as inhibition, in the whole organism at one dose (the size of the read-out at that dose, not a potency): 61.3%
For compound 4 the middle estimate is 6.3 percentage points below the measured one; measured number inside the range.
By their numbers in this assay, from the lowest: compounds 3, 1 and 4 (each within the scatter of the next); then compound 2.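

In this assay, the 4-(dimethylamino)phenyl group on this carbon with a double bond to nitrogen cannot be told apart from the two groups it is compared with here, with a number 3 percentage points higher from compound 1 to compound 4 (within the scatter) and a number 9.9 percentage points higher from compound 3 to compound 4 (within the scatter). The 3-chlorophenyl group alone stands apart from it, with a number 16.5 percentage points lower from compound 2 to compound 4 (beyond the scatter), so three differently substituted phenyl groups now sit at one level and compound 2 sits above them. Nothing given here explains this separation.

The compounds shown leave open whether a 3-bromophenyl group would reach the level of compound 2, and whether a cyclohexyl group would hold the level of compound 1.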